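The source may report more compounds than this note shows. Statements on the series, on what has been measured and on what is new or still open speak of the compounds shown alone.

Going by the values given here, in a functional assay on the whole organism with Rattus norvegicus as the target (a lower number here means that less compound is needed, a higher number that more compound is needed for the effect), compound 1 (`C[Si](C)(C)c1ccc2nc(N)sc2c1`) gives 5 mg/kg, the only actual number so far. Compound 2 (`Nc1nc2ccc(C3CCCCC3)cc2s1`) gives > 10 mg/kg, which is a limit of the assay. Compound 3 (`Nc1nc2ccc(C(=O)C(F)(F)F)cc2s1`) gives > 10 mg/kg, also a limit. Compound 4 (`Nc1nc2ccc(SC(F)(F)F)cc2s1`) keeps the core of compound 1 and carries (trifluoromethyl)sulfanyl on the same aromatic carbon: a group of 5 heavy atoms (1 carbon, 3 fluorine, 1 sulfur; no ring) in place of a group of 4 heavy atoms (3 carbon, 1 silicon; no ring), on an aromatic carbon. Among the compounds with values here, no measured step between compounds differing in one place is available to anchor this change. A small step toward a lower dose is expected, a 1.7-fold lower number from compound 1 to compound 4 (0.22 log units; within the scatter), and this remains a weakly founded estimate. For compound 4 the estimated value in this assay is 3 mg/kg, with an expected range of 1.2 mg/kg to 8 mg/kg.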

Compound 4, dose for half-maximal effect: 8 mg/kg
Estimate against measurement, compound 4: 2.7-fold (0.43 log units) below; low and high end bracket the measured number.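

In this assay the exchange gives a 1.6-fold higher number from compound 1 to compound 4 (0.20 log units; within the scatter), so the group of compound 1 and (trifluoromethyl)sulfanyl cannot be told apart at this aromatic carbon. Compound 4 is a second compound with an actual number rather than a limit, and the hydrogen-bond acceptor on the entering group brings no step beyond the scatter. The room for reading the series remains narrow: the limit of > 10 mg/kg in this assay, at which 2 of the 4 values shown sit.

From the compounds shown here alone, whether an amine, a carboxylic acid or a longer alkyl chain on this aromatic carbon would move the dose beyond the scatter stays open. So does the outcome of any change elsewhere on the shared core.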